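Sulfonyl side chain variation and stability in liver microsomes

The source may hold more compounds than are shown below. What is called first, only, known or untested is meant among the compounds shown, and "the series" means these compounds.

The shared core of compound 1 `CC(C)NCCS(=O)(=O)NC(=O)c1ccc(Nc2nc(NC3(c4ccc(Cl)cc4)CC3)nc(OCC(F)(F)F)n2)cc1` carries on its sulfonyl sulfur a 2-(isopropylamino)ethyl group. Among the measured compounds shown here, in an ADME assay on microsomes from liver (Homo sapiens) for metabolic stability, with a stated time of 10 min (a lower number here means that less of the compound is left, a higher number that more of the compound is left), compound 1 gives 89%, the lowest of the two numbers so far. Its nearest neighbour is compound 2 `O=C(NS(=O)(=O)C1CC1)c1ccc(Nc2nc(NC3(c4ccc(Cl)cc4)CC3)nc(OCC(F)(F)F)n2)cc1`, which in this assay gives 100%; the step of a number 11 percentage points higher from compound 1 to compound 2 (beyond the scatter) goes with cyclopropyl in place of 2-(isopropylamino)ethyl on the sulfonyl sulfur.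

Compound 3 `CNC(=O)NCCS(=O)(=O)NC(=O)c1ccc(Nc2nc(NC3(c4ccc(Cl)cc4)CC3)nc(OCC(F)(F)F)n2)cc1` differs from compound 1 at a different point: methylcarbamoyl in place of isopropyl on an amine nitrogen. For the measured compounds named here, no measured step covers this exact exchange. Going by the values given here, the single step available, a number 11 percentage points higher from compound 1 to compound 2 (beyond the scatter), replaces the whole side chain rather than its terminal isopropyl, so it speaks only loosely to the question. Because compound 1 already gives 89%, there is little room above it, and the new urea-type end is not expected to move the number far beyond the scatter. The step of a number 4 percentage points higher from compound 1 to compound 3 (within the scatter) is therefore expected to be small and, if anything, upward. In this assay compound 3 is estimated at 93%, with a range from 80% to 100%.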

Compound 3, percent of the compound remaining: 97%
Beside the measured number, compound 3's estimate is 4 percentage points below it; the range from low to high includes it.
By their numbers in this assay, from the lowest: compounds 1, 3 and 2 (each within the scatter of the next, the first and the last beyond it).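

With methylcarbamoyl in place of isopropyl on the amine nitrogen, the side chain keeps its 2-ethyl length and only its end is exchanged, and this goes with a number 8 percentage points higher from compound 1 to compound 3 (within the scatter) in this assay. Compound 1 and compound 2 had shown only that replacing the whole side chain gives a step beyond the scatter, whereas this result shows that a change confined to the end of the chain stays inside it, and a number 3 percentage points lower from compound 2 to compound 3 (within the scatter) places the 2-((methylcarbamoyl)amino)ethyl group level with cyclopropyl on the sulfonyl sulfur. Nothing at hand gives a reason for either of these steps.

Going by these compounds, whether a carboxylic acid, a morpholine or a plain primary amine at the end of the chain, or a longer chain in place of the 2-((methylcarbamoyl)amino)ethyl group, would also stay within the scatter remains open. On these data alone, it also remains open whether the side chains would separate more clearly under conditions where less of each compound is left, since all the numbers in this assay lie close to the top of the read-out.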